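A Nitro Swap on the Aryl Piperazine Thiocarbamate Series

This account rests on a few compounds, and the source may have more. Where it says the series, first, only, none or still open, it means among the compounds named here.

Measured in a functional assay on A549 cells (Homo sapiens) for antiproliferative activity, read by MTT assay, with a stated time of 72 h; a higher number here means a weaker inhibitor, a lower number a stronger inhibitor:
Compound 1 `Nc1nc(N)c2cc(CSC(=S)N3CCN(c4ccc(O)cc4)CC3)ccc2n1`: 4210 nM
Compound 2 `Nc1nc(N)c2cc(CSC(=S)N3CCN(c4ccc(F)cc4)CC3)ccc2n1`: 2040 nM

Of these two compounds, compound 2 holds the lower number, at 2040 nM, which makes it the stronger inhibitor of the pair. For the measured compounds named here, its only neighbour, compound 1, gives 4210 nM.

The next compound, compound 3 `Nc1nc(N)c2cc(CSC(=S)N3CCN(c4ccc([N+](=O)[O-])cc4)CC3)ccc2n1`, keeps everything in compound 2 except one group: nitro in place of fluoro on an aromatic carbon, para to a large group (nitro in place of fluoro on an aromatic carbon).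

Going by the values given here, only one measured step bears on this change. It concerns the same ring position, where fluoro took the place of hydroxy, and it shows a 2.1-fold lower number from compound 1 to compound 2 (0.31 log units; beyond the scatter). Among the compounds with values here, that step is modest, and no measured compound carries a nitro group, so the data do not settle the direction of the new step. A step of similar or smaller size is therefore expected in this assay, with a slightly higher number only marginally favoured.

The estimated change is a 1.2-fold higher number from compound 2 to compound 3 (0.09 log units; within the scatter).

For compound 3 the expected value is 2500 nM, with an estimated range from 900 nM to 7000 nM.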

Compound 3, half-maximal inhibitory concentration: 1910 nM
Compound 3: the middle estimate sits 1.3-fold (0.12 log units) above what was measured; measured number inside the range.
By their numbers in this assay, from the lowest: compounds 3 and 2 (each within the scatter of the next); then compound 1.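

In this assay, nitro in place of fluoro gives a 1.1-fold lower number from compound 2 to compound 3 (0.03 log units; within the scatter), so these two groups cannot be told apart at this position, even though nitro brings three heavy atoms and two hydrogen-bond acceptors where fluoro brings one heavy atom and no acceptors. Nitro in place of hydroxy gives a 2.2-fold lower number from compound 1 to compound 3 (0.34 log units; beyond the scatter), a modest step much like the earlier one with fluoro, a 2.1-fold lower number from compound 1 to compound 2 (0.31 log units; beyond the scatter), so two quite different groups now stand apart from hydroxy by about the same amount, and on these three compounds alone it is the hydroxy compound that differs from the other two. Nothing measured here explains why these numbers fall as they do.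

For the compounds shown here, with only three groups compared, it remains open whether an amine, a carboxylic acid or a plain hydrogen on this ring carbon would sit with hydroxy or with fluoro and nitro. From the compounds shown here alone, it also remains open whether a larger group, such as a longer chain, would keep the number where it is or move it well beyond the scatter.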